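The compounds below may be only part of what the source reports. "The series", "measured", "known", "first", "only" and "open" are said of these compounds alone.

Compound 1, `COc1cc2ncnc(Nc3cccc(Br)c3)c2cc1OCCCCC(=O)Nc1ccc(S(N)(=O)=O)cc1`, gives 14900 nM in a functional assay on A549 cells (Homo sapiens) for antiproliferative activity, read by MTT assay, with a stated time of 72 h; a higher number here means a weaker inhibitor, a lower number a stronger inhibitor.
Compound 2, `COc1cc2ncnc(Nc3cccc(F)c3)c2cc1OCCCCC(=O)Nc1ccc(S(N)(=O)=O)cc1`, gives only the assay's limit, > 40000 nM, in this assay.
Compound 3, `COc1cc2ncnc(Nc3ccc(F)cc3)c2cc1OCCCCC(=O)Nc1ccc(S(N)(=O)=O)cc1`, likewise gives only the limit, > 40000 nM, in this assay.

Three compounds share one core and differ only in the aryl group on the amine. From the compounds shown here alone, compound 2 stands at the limit of this assay, so its true value is unknown; the same holds for compound 3, as the limit of > 40000 nM in this assay, at which 2 of the 3 values shown sit, shows. Only compound 1, with its bromo group, gives a readable number.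

Compound 4, `COc1cc2ncnc(Nc3cccc(Cl)c3F)c2cc1OCCCCC(=O)Nc1ccc(S(N)(=O)=O)cc1`, has not yet been measured. It differs from compound 2 in one place: 3-chloro-2-fluorophenyl in place of 3-fluorophenyl on a nitrogen on an aromatic ring. The change adds a chlorine while keeping a fluorine on the ring.

Within the data shown here, two measured steps bear on this. Going from bromo to fluoro gave an at least 2.6-fold higher number from compound 1 to compound 2 (0.42 log units; beyond the scatter), and moving to the 4-fluorophenyl gave an at least 2.6-fold higher number from compound 1 to compound 3 (0.42 log units; beyond the scatter). The step between compound 2 and compound 3 is unreadable, as a step that the two limits leave unreadable from compound 2 to compound 3 states. Among the measured compounds shown here, a heavier halogen on the ring went with the only readable value, so a return of a chlorine in compound 4 is expected to bring the number at least partly back toward that of compound 1, though a limit again remains possible. The expected step is an at least 1.6-fold lower number from compound 2 to compound 4 (0.20 log units; that floor lies within the scatter), and compound 4 is estimated at 25000 nM, between 8000 nM and 80000 nM.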

Compound 4, half-maximal inhibitory concentration: 10500 nM
The estimate for compound 4 lay 2.4-fold (0.38 log units) above the measured number; the measured number falls inside the stated range.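

Putting 3-chloro-2-fluorophenyl on the amine nitrogen gives a second readable number in this assay: in place of 3-fluorophenyl it gives an at least 3.8-fold lower number from compound 2 to compound 4 (0.58 log units; beyond the scatter), and in place of 4-fluorophenyl it gives an at least 3.8-fold lower number from compound 3 to compound 4 (0.58 log units; beyond the scatter). These two sizes are only floors, not exact steps, because compound 2 and compound 3 each give only a limit of the assay: the limit of > 40000 nM in this assay, at which 2 of the 4 values shown sit. In place of 3-bromophenyl, the new group gives a 1.4-fold lower number from compound 1 to compound 4 (0.15 log units; within the scatter), so the two compounds cannot be told apart, and among these four compounds a readable number now goes with a ring carrying a bromine or a chlorine, while the two rings carrying only a fluorine stay at the limit.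

The compounds shown do not separate the part played by the chlorine from that of the fluorine in 3-chloro-2-fluorophenyl, a question that a plain 3-chlorophenyl group would address. They also leave open whether a ring with no halogen, such as 3-methoxyphenyl, or a longer chain leading to the sulfonamide end would give a lower number than compound 1 and compound 4 do.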